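Trifluoromethylphenyl position shift: notes ahead of the measurement

A few compounds are considered here, and "the series" means these few. Any claim that something is new, unique, unknown or untested is made for them only; others in the source may bear on it.

Compound 1 `Oc1ccc(-c2cc(-c3ccccc3F)cc(-c3ccc(O)cc3)n2)cc1` gives 15100 nM in a functional assay on T47D cells (Homo sapiens) for inhibition; on this read-out lower numbers stand for stronger inhibition and higher numbers for weaker inhibition.
Compound 2 `Oc1ccc(-c2cc(-c3cccc(F)c3)cc(-c3ccc(O)cc3)n2)cc1` reaches only the assay limit > 50000 nM in this assay.
Compound 3 `Oc1ccc(-c2cc(-c3cccc(C(F)(F)F)c3)cc(-c3ccc(O)cc3)n2)cc1` likewise reaches only the assay limit > 50000 nM in this assay.

Compound 3 therefore stands at a limit, not a number, a limit shared by two of three values (the limit of > 50000 nM in this assay, at which 2 of the 3 values shown sit); compound 1 alone gives a readable value. Compound 4 `Oc1ccc(-c2cc(-c3ccc(C(F)(F)F)cc3)cc(-c3ccc(O)cc3)n2)cc1` differs from compound 3 by 4-(trifluoromethyl)phenyl in place of 3-(trifluoromethyl)phenyl on an aromatic carbon. The steps on record, an at least 3.3-fold higher number from compound 1 to compound 2 (0.51 log units; beyond the scatter) and an at least 3.3-fold higher number from compound 1 to compound 3 (0.51 log units; beyond the scatter), both run toward the limit, while a step that the two limits leave unreadable from compound 2 to compound 3. Among the compounds with values here, no measured step compares the 3- and 4-substituted phenyl directly, so the expected step is a number no higher from compound 3 to compound 4 (the limit leaves the size open), most likely another limit. Compound 4 is estimated at 50000 nM, range 15000 nM to 150000 nM.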

Compound 4, half-maximal inhibitory concentration: > 50000 nM
Compound 4 ended at the assay's limit (the forecaster's own chance of this, stated with the estimate: 70%); the middle value lies on the limit itself.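

Neither 3-(trifluoromethyl)phenyl nor 4-(trifluoromethyl)phenyl at this position, opposite the ring nitrogen, gives a readable value, so this shift of the trifluoromethyl group recovers no measurable inhibition. Against 2-fluorophenyl, the change gives an at least 3.3-fold higher number from compound 1 to compound 4 (0.51 log units; beyond the scatter). The steps among compound 2, compound 3 and compound 4 cannot be read, and the limit now covers most of the set: the limit of > 50000 nM in this assay, at which 3 of the 4 values shown sit.

From the compounds shown here alone, how far compound 2, compound 3 and compound 4 lie past the limit stays open. Also open, going by these compounds, is how an amine or a carboxylic acid would read in place of the trifluoromethyl group.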